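The source may report more compounds than this note shows. Statements on the series, on what has been measured and on what is new or still open speak of the compounds shown alone.

Working notes on the series. Two members of the set have been run in a functional assay for agonist activity at G protein-coupled receptor 88 (Homo sapiens), read by HTRF and cAMP accumulation; a lower number here means that less compound is needed, a higher number that more compound is needed for the effect. Compound 1, `CC(C)C[C@H](N)CN(C(=O)[C@@H]1C[C@H]1c1ccccc1)c1ccc(-c2ccc(C#N)cc2)cc1`, gives 670 nM. Compound 2, `CCCc1ccc(-c2ccc(N(C[C@@H](N)[C@@H](C)CC)C(=O)[C@@H]3C[C@H]3c3ccccc3)cc2)cc1`, gives 61 nM. Compound 2 holds the lowest number of the two; the nearest is compound 1, whose number lies higher by more than the usual scatter. These two compounds differ from each other in more than one place, so the gap between them cannot be tied to a single change.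

Compound 3, `CC[C@H](C)[C@H](N)CN(C(=O)[C@@H]1C[C@H]1c1ccccc1)c1ccc(-c2ccc(OC(F)(F)F)cc2)cc1`, is the next member to be measured. It differs from compound 2 in one place: trifluoromethoxy in place of propyl on an aromatic carbon. The rest of compound 2 is kept unchanged.

Among the measured compounds shown here, no pair of measured compounds in this set isolates a change at this position, so no measured step anchors the expectation. On the numbers shown, a modest rise in this assay is expected, a 2.5-fold higher number from compound 2 to compound 3 (0.39 log units; beyond the scatter), small enough that it may not clear the scatter. Compound 3 is accordingly expected to give 150 nM in this assay, within a range from 50 nM to 500 nM.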

Compound 3, half-maximal effective concentration: 170 nM
The estimate for compound 3 lay 1.1-fold (0.05 log units) below the measured number, within the range that was stated.
By their numbers in this assay, from the lowest: compound 2; then compound 3; then compound 1.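

Among the compounds shown here, this is the first change in the set that can be read at a single place. In this assay, trifluoromethoxy in place of propyl on the aromatic carbon para to a large group gives a 2.8-fold higher number from compound 2 to compound 3 (0.45 log units; beyond the scatter), a modest step in the direction of a higher number. At this position, then, exchanging a three-carbon chain with no hydrogen-bond acceptor for a group of five heavy atoms with one hydrogen-bond acceptor moves the number only modestly, and no evidence on the cause of the step is at hand.

A single pair cannot separate the part played by the oxygen from that of the fluorines, and a methoxy or a trifluoromethyl group at the same carbon would divide the two, while a longer chain such as butyl would show how far the propyl end can be extended. The compounds shown also leave open whether the same step would hold with a different amide group on the shared core.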